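The source may report more compounds than this note shows. Statements on the series, on what has been measured and on what is new or still open speak of the compounds shown alone.

Values in an ADME assay on PBMC cells (Homo sapiens) for cytotoxicity, with a stated time of 5 days; a lower number here means that less compound is tolerated, a higher number that more compound is tolerated:
- Compound 1 `C[C@@]1(O)[C@H](O)[C@@H](CO)O[C@H]1n1cnc2c(N)nc(NN)nc21`: > 100000 nM (a limit)
- Compound 2 `C[C@@]1(O)[C@H](O)[C@@H](CO)O[C@H]1n1cnc2c(N)nc(N=[N+]=[N-])nc21`: > 100000 nM (a limit)

Compound 2 gives > 100000 nM, which is a limit and not a number. Going by the values given here, the series so far shows (the limit of > 100000 nM in this assay, at which 2 of the 2 values shown sit), so compound 2 has no readable rank against compound 1.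

Compound 3 `C[C@@]1(O)[C@H](O)[C@@H](CO)O[C@H]1n1cnc2c(N)nc(-n3cc([Si](C)(C)C)nn3)nc21` differs from compound 2 on an aromatic carbon of the shared core: a group of 9 heavy atoms (5 carbon, 3 nitrogen, 1 silicon; one five-membered aromatic ring with 3 hetero atoms) in place of a group of 3 heavy atoms (3 nitrogen; no ring), on an aromatic carbon.

Among the compounds with values here, the one measured step, a step that the two limits leave unreadable from compound 1 to compound 2, concerns the same aromatic carbon but has no readable size, so it offers no measured size to carry over. With only this to go on, no change beyond the scatter is expected in this assay, and the expected step is a number no higher from compound 2 to compound 3 (the limit leaves the size open). For compound 3 the estimated value is 100000 nM, with an expected range from 30000 nM to 100000 nM.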

Compound 3, half-maximal cytotoxic concentration: > 100000 nM
Compound 3: no number, only a limit (the forecaster's own chance of this, stated with the estimate: 75%); the middle value sits exactly at the limit.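

No new step can be read among compound 1, compound 2 and compound 3 in this assay, because all three give a limit and not a number: the limit of > 100000 nM in this assay, at which 3 of the 3 values shown sit. The compounds shown leave open how far apart these three lie and whether any group on this aromatic carbon gives a readable value.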